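Amide aryl change on a fluoro-flavonol series

A few compounds are considered here, and "the series" means these few. Any claim that something is new, unique, unknown or untested is made for them only; others in the source may bear on it.

The two measured compounds share one core. Compound 1 `Cc1cccc(C(=O)Nc2cccc(-c3oc4cc(-c5ccc(F)cc5)ccc4c(=O)c3O)c2)c1` gives 16500 nM in a functional assay on A549 cells (Homo sapiens) for antiproliferative activity, read by CCK-8 assay, with a stated time of 72 h; on this read-out lower numbers stand for stronger inhibition and higher numbers for weaker inhibition; compound 2 `O=C(Nc1cccc(-c2oc3cc(-c4ccc(F)cc4)ccc3c(=O)c2O)c1)c1cccc(F)c1` gives 15400 nM in this assay. Going by the values given here, compound 2 thus holds the lowest of the two numbers, with compound 1 within the scatter of it, and the only step seen so far, a 1.1-fold lower number from compound 1 to compound 2 (0.03 log units; within the scatter), lies within that scatter. Compound 3 `COc1ccc(C(=O)Nc2cccc(-c3oc4cc(-c5ccc(F)cc5)ccc4c(=O)c3O)c2)c(F)c1` differs from compound 2 by 2-fluoro-4-methoxyphenyl in place of 3-fluorophenyl on a carbonyl carbon. Among the compounds with values here, no measured step bears directly on this change, so no shift beyond the scatter is expected; the estimated step is a 1.1-fold lower number from compound 2 to compound 3 (0.04 log units; within the scatter). Compound 3 is therefore estimated at 14000 nM, in the range 5000 nM to 40000 nM.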

Compound 3, half-maximal inhibitory concentration: 40000 nM
Beside the measured number, compound 3's estimate is 2.9-fold (0.46 log units) below it; measured number inside the range.
By their numbers in this assay, from the lowest: compounds 2 and 1 (each within the scatter of the next); then compound 3.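

In this assay the group on the carbonyl carbon now matters, with a 2.6-fold higher number from compound 2 to compound 3 (0.41 log units; beyond the scatter) and a 2.4-fold higher number from compound 1 to compound 3 (0.38 log units; beyond the scatter) in this series, while the earlier swap from 3-methylphenyl to 3-fluorophenyl moved nothing beyond the scatter. Of these three compounds, compound 3, with 2-fluoro-4-methoxyphenyl, shows the weakest inhibition. Nothing at hand explains this shift. On these data alone, the fluoro and the methoxy enter together, so their separate contributions remain open. As far as these compounds go, whether an amine or a carboxylic acid on this aromatic ring would lower the number also remains open.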